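Swapping a propyl for a cyclohexyl on a sulfonylurea

This account rests on a few compounds, and the source may have more. Where it says the series, first, only, none or still open, it means among the compounds named here.

Three compounds share one core and were tested in a functional assay on the whole organism (blood, strain Wistar albino) for inhibition, with Rattus norvegicus as the target, read by colorimetric assay, with stated times of 15 min and 90 min, at a dose of 20 mg/kg by the oral route; on this read-out higher numbers stand for more inhibition at the one dose given (going by the name of the read-out) and lower numbers for less inhibition. Compound 1 `O=C(NC1CCCCC1)NS(=O)(=O)c1ccc(-n2nc(-c3ccccc3)ccc2=O)cc1` gives 52.1%, compound 2 `Cc1ccc(-c2ccc(=O)n(-c3ccc(S(=O)(=O)NC(=O)NC4CCCCC4)cc3)n2)cc1` gives 79.9%, and compound 3 `CCCNC(=O)NS(=O)(=O)c1ccc(-n2nc(-c3ccc(Cl)cc3)ccc2=O)cc1` gives 74.3%. On these numbers compound 3 stands second highest: its gap to compound 2 lies within the scatter, while compound 1 sits lower by a margin beyond it. Within the data shown here, the only measured step, a number 27.8 percentage points higher from compound 1 to compound 2 (beyond the scatter), concerns a different place. Compound 4 `O=C(NC1CCCCC1)NS(=O)(=O)c1ccc(-n2nc(-c3ccc(Cl)cc3)ccc2=O)cc1` arises from compound 3 by cyclohexyl in place of propyl on an amide-type nitrogen. Among the measured compounds shown here, no measured pair isolates this change, so the size of the step is expected to stay within the scatter, as a number 1.7 percentage points higher from compound 3 to compound 4 (within the scatter). Compound 4 is therefore estimated at 76%, between 58% and 90%.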

Compound 4, a percentage reported as inhibition, in the whole organism at one dose (the size of the read-out at that dose, not a potency): 59%
Compound 4: middle estimate off by 17 percentage points, on the high side; measured number inside the range.
By their numbers in this assay, from the lowest: compounds 1 and 4 (each within the scatter of the next); then compounds 3 and 2 (each within the scatter of the next).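

On the amide-type nitrogen, cyclohexyl in place of propyl is not a neutral swap in this assay: with the chloro group kept, the change gives a number 15.3 percentage points lower from compound 3 to compound 4 (beyond the scatter). With cyclohexyl kept, chloro in place of methyl on the aromatic carbon gives a number 20.9 percentage points lower from compound 2 to compound 4 (beyond the scatter), while chloro in place of hydrogen gives a number 6.9 percentage points higher from compound 1 to compound 4 (within the scatter), so on that carbon only methyl stands apart. No evidence is available to explain either result.

On these data alone, whether a butyl or a cyclopentyl on that nitrogen would behave more like propyl or like cyclohexyl stays open. So does whether the swap has the same effect with methyl or hydrogen in place of chloro on the aromatic carbon.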